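Chloro for methyl on the shared core of compound 2

The compounds below may be only part of what the source reports. "The series", "measured", "known", "first", "only" and "open" are said of these compounds alone.

Three compounds have numbers in a functional assay on NUGC-3 cells (Homo sapiens) for antiproliferative activity, read by XTT assay; on this read-out lower numbers stand for stronger inhibition and higher numbers for weaker inhibition. Compound 1 `O=c1c(Cc2coc3cccc(OCC4CCCCC4)c3c2=O)coc2cc(O)ccc12` gives 3220 nM. Compound 2 `Cc1ccc2c(=O)c(Cc3coc4cccc(OCC5CCCCC5)c4c3=O)coc2c1` gives 2150 nM, the lowest of the three, though its gaps to the other two lie within the scatter. Compound 3 `O=c1c(Cc2coc3cccc(O)c3c2=O)coc2ccccc12` gives 3270 nM; compound 2 and compound 3 thus differ by a gap within the scatter. Within the data shown here, the only single-point step measured so far, a 1.5-fold lower number from compound 1 to compound 2 (0.18 log units; within the scatter), changed nothing beyond the scatter.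

Compound 4 `O=c1c(Cc2coc3cccc(OCC4CCCCC4)c3c2=O)coc2cc(Cl)ccc12` differs from compound 2 by chloro in place of methyl on an aromatic carbon. Among the measured compounds shown here, no measured step swaps chloro for methyl at this place; the one step at this place, hydroxy to methyl, stayed within the scatter. Nothing in the series therefore argues for a step beyond the scatter in this assay, and the expectation is a number close to that of compound 2, with the step of a 1.0-fold lower number from compound 2 to compound 4 (0.01 log units; within the scatter) taken as estimate. For compound 4 the expected value is 2100 nM, with a range from 1000 nM to 4500 nM.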

Compound 4, half-maximal inhibitory concentration: > 10000 nM
Compound 4: no number, only a limit; the forecaster's own chance of this, stated with the estimate: 5%; at least 4.7-fold (0.67 log units) between middle value and limit.
By their numbers in this assay, from the lowest: compounds 2, 1 and 3 (each within the scatter of the next). At a limit, above all of these: compound 4.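

Notes on this position: in this assay the place on the shared core is not indifferent to its substituent, as chloro gives weaker inhibition than either group held there before, with an at least 4.6-fold higher number from compound 2 to compound 4 (0.66 log units; beyond the scatter) and with an at least 3.1-fold higher number from compound 1 to compound 4 (0.49 log units; beyond the scatter). Among these compounds, the earlier step between hydroxy and methyl stayed within the scatter, so this is the first change at this place to move the number beyond it. Both steps have only a lower bound, since the reading for compound 4 is a limit and not a number: the limit of > 10000 nM in this assay, at which 1 of the 4 values shown sits.

As far as these compounds go, how far compound 4 actually lies past that limit stays open. Also open, from the compounds shown here alone, is whether the weakening is peculiar to chloro or extends to other groups at this place, such as fluoro, methoxy, an amine or a carboxylic acid.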